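A few compounds are considered here, and "the series" means these few. Any claim that something is new, unique, unknown or untested is made for them only; others in the source may bear on it.

Working notes on a short series of agonists compared in a functional assay on CHO cells for agonist activity at Alpha-1A adrenergic receptor (Homo sapiens), read by FLIPR and calcium flux; a higher number here means a larger maximal response, a lower number a smaller maximal response. Compound 1 `Cn1ccc(-c2cccc3c2CCC3c2ncc[nH]2)n1` gives 19%, compound 2 `Cn1nccc1-c1cccc2c1CCC2c1ncc[nH]1` gives 58%, and compound 3 `CS(=O)(=O)Nc1c(Cl)ccc2c1CCCC2c1ncc[nH]1` gives 61%. Compound 2 thus stands second highest of the three numbers, within the scatter of compound 3 and beyond the scatter from compound 1. Going by the values given here, the only measured single-point step, a number 39 percentage points higher from compound 1 to compound 2 (beyond the scatter), shows that this place of the shared core moves the maximal response strongly. Compound 4 `CNC(=O)c1cccc2c1CCC2c1ncc[nH]1` is not yet measured; against compound 2 the change is methylcarbamoyl in place of 1-methyl-1H-pyrazol-5-yl on an aromatic carbon. Among the compounds with values here, no measured step replaces the 1-methyl-1H-pyrazol-5-yl with a group lacking a ring, so the direction is uncertain, with a downward step of moderate size thought more likely. For compound 4 the estimate is 35%, between 10% and 65%, which means an expected step of a number 23 percentage points lower from compound 2 to compound 4 (beyond the scatter).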

Compound 4, largest response reached (Emax), in percent of the reference or control that the assay uses: 59%
Compound 4: the middle estimate sits 24 percentage points below what was measured; measured number inside the range.
By their numbers in this assay, from the lowest: compound 1; then compounds 2, 4 and 3 (each within the scatter of the next).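

The step of a number 1 percentage points higher from compound 2 to compound 4 (within the scatter) shows that in this assay methylcarbamoyl, which has no ring, gives a maximal response matching that of 1-methyl-1H-pyrazol-5-yl at this aromatic carbon. A five-membered aromatic ring is therefore not required here. Going by these compounds alone, the step of a number 40 percentage points higher from compound 1 to compound 4 (beyond the scatter) leaves 1-methyl-1H-pyrazol-3-yl as the only one of the three groups at this place with a low response. No supporting data bear on the reason for this result. Open, as far as these compounds go, is whether a carboxylic acid, a primary amine or a longer chain on the amide nitrogen would keep the response at this place.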